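An iodinated aniline replaces a chlorofluorophenyl arm

The source may report more compounds than this note shows. Statements on the series, on what has been measured and on what is new or still open speak of the compounds shown alone.

Compound 1 `COc1cc2c(Nc3cc(C(F)(F)F)ccc3F)ncnc2c(OC)c1OC`: in a functional assay on SGC-7901 cells (Homo sapiens) for antiproliferative activity, read by MTT assay, with a stated time of 72 h (a higher number here means a weaker inhibitor, a lower number a stronger inhibitor), compound 1 gives 10300 nM.
Compound 2 `COc1cc2c(Nc3ccc(Cl)cc3F)ncnc2c(OC)c1OC`: in this assay compound 2 gives > 30000 nM, which is a limit of the assay and not a number.
Compound 3 `COc1cc2c(Nc3ccc(F)c(Cl)c3F)ncnc2c(OC)c1OC`: in this assay compound 3 gives > 30000 nM, likewise a limit and not a number.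

Compound 2 therefore stands at the limit of > 30000 nM in this assay, at which 2 of the 3 values shown sit, and of the three compounds shown only compound 1 has a measured number in this assay. Compound 4 `COc1cc2c(Nc3cccc(I)c3)ncnc2c(OC)c1OC` differs from compound 2 by 3-iodophenyl in place of 4-chloro-2-fluorophenyl on a nitrogen on an aromatic ring. No step between measured compounds is shown, so the size of this change cannot be read from any measured pair, and the author can only say that compound 1 proves a number within reach of this assay for this shared core. On that basis the step from compound 2 to compound 4 is expected to be an at least 3.7-fold lower number from compound 2 to compound 4 (0.57 log units; beyond the scatter), in the direction of stronger inhibition but with wide uncertainty. Compound 4 is thus estimated at 8000 nM, with a range from 2000 nM to 30000 nM, and a real chance remains that it too is reported only as a limit.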

Compound 4, half-maximal inhibitory concentration: 8640 nM
Estimate against measurement, compound 4: 1.1-fold (0.03 log units) below; the measured number falls inside the stated range.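

In this assay, the place on a nitrogen on an aromatic ring now has a step that can be read: 3-iodophenyl in place of 4-chloro-2-fluorophenyl gives an at least 3.4-fold lower number from compound 2 to compound 4 (0.54 log units; beyond the scatter). This is the first measured pair among the compounds shown, and it indicates that changing this one group can take the shared core from a limit to a measured number. The step gives only a lower bound on the change, since its starting point is a limit of the assay and not a number: the limit of > 30000 nM in this assay, at which 2 of the 4 values shown sit.

The step removes the chlorine and the fluorine and brings in the iodine all at once, so the compounds shown do not tell which of these changes matters. From the compounds shown here alone, whether a bromophenyl group, or a phenyl ring carrying an amine or a carboxylic acid, would also give a measured number in this assay remains open.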